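Piperazine Nitrogen Substituent in a Triazine Series

The compounds below may be only part of what the source reports. "The series", "measured", "known", "first", "only" and "open" are said of these compounds alone.

For the measured compounds named here, compound 2 `CCN1CCN(c2nc(Nc3ccc(C#N)c(C(F)(F)F)c3)nc(Oc3ccnc4ccccc34)n2)CC1` gives 86600 nM in a functional assay on DU-145 cells (Homo sapiens) for cytotoxicity, read by sulforhodamine B assay, with a stated time of 48 h (on this read-out higher numbers stand for weaker inhibition of growth and lower numbers for stronger inhibition of growth), the higher of the two numbers measured so far, while compound 1 `CC1CC(C)CN(c2nc(Nc3ccc(C#N)c(C(F)(F)F)c3)nc(Oc3ccnc4ccccc34)n2)C1` gives 27200 nM. Going by the values given here, the only measured step, a 3.2-fold higher number from compound 1 to compound 2 (0.50 log units; beyond the scatter), exchanged the whole ring on the aromatic carbon and therefore does not isolate the change to compound 3 `N#Cc1ccc(Nc2nc(Oc3ccnc4ccccc34)nc(N3CCN(c4ncccn4)CC3)n2)cc1C(F)(F)F`, which is pyrimidin-2-yl in place of ethyl on an amine nitrogen in a ring. Among the compounds with values here, no measured step tests a pyrimidin-2-yl on this nitrogen, so the direction stays open, and a return toward the region of compound 1 is as plausible as no change beyond the scatter. Compound 3 is expected at 40000 nM (range 10000 nM to 150000 nM), an expected step of a 2.2-fold lower number from compound 2 to compound 3 (0.34 log units; beyond the scatter).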

Compound 3, concentration for 50% growth inhibition: 85200 nM
The estimate for compound 3 lay 2.1-fold (0.33 log units) below the measured number; the range from low to high includes it.
By their numbers in this assay, from the lowest: compound 1; then compounds 3 and 2 (each within the scatter of the next).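

On the amine nitrogen of the piperazine ring, pyrimidin-2-yl in place of ethyl leaves the number unchanged within the scatter (a 1.0-fold lower number from compound 2 to compound 3 (0.01 log units; within the scatter)), so adding this aromatic ring at this position does not alter growth inhibition in these two compounds. Compound 3 also stands apart from the 3,5-dimethylpiperidin-1-yl compound (a 3.1-fold higher number from compound 1 to compound 3 (0.50 log units; beyond the scatter)), a step of the same size as (a 3.2-fold higher number from compound 1 to compound 2 (0.50 log units; beyond the scatter)). No experimental evidence at hand explains these results.

Still open, as far as these compounds go, is whether a carboxylic acid or a longer chain on this nitrogen would move the number. Also open, from the compounds shown here alone, is whether a piperazine carrying any other group can reach the region of compound 1.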